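This account rests on a few compounds, and the source may have more. Where it says the series, first, only, none or still open, it means among the compounds named here.

In a functional assay on HT-29 cells (Homo sapiens) for inhibition, read by MTT assay, with a stated time of 72 h (on this read-out lower numbers stand for stronger inhibition and higher numbers for weaker inhibition), compound 1 `COc1cc(Oc2cccc(Nc3ccccc3)c2)cc(OC)c1CNCc1ccccc1` gives 3340 nM, compound 2 `CNCc1c(OC)cc(Oc2cccc(Nc3ccccc3)c2)cc1OC` gives 7430 nM and compound 3 `COc1cc(Oc2cccc(Nc3ccccc3)c2)cc(OC)c1CNCCNC(C)=O` gives 3960 nM. Compound 3 stands in the middle of these three numbers but within the scatter of both others, with a 1.2-fold higher number from compound 1 to compound 3 (0.07 log units; within the scatter) and a 1.9-fold lower number from compound 2 to compound 3 (0.27 log units; within the scatter). Only the removal of the phenyl goes beyond the scatter, with a 2.2-fold higher number from compound 1 to compound 2 (0.35 log units; beyond the scatter), and that step is modest.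

Compound 4 `COc1cc(Oc2cccc(Nc3ccccc3)c2)cc(OC)c1CN[C@H](C)c1ccccc1` has not yet been measured. It differs from compound 3 on the amine nitrogen: 1-phenylethyl in place of 2-acetamidoethyl on an amine nitrogen. In words, this is 1-phenylethyl in place of 2-acetamidoethyl on an amine nitrogen. The closest evidence is the exchange of phenyl for acetamidomethyl on a saturated chain carbon bound to an amine nitrogen, where a 1.2-fold higher number from compound 1 to compound 3 (0.07 log units; within the scatter) stays within the scatter. Going by the values given here, compound 4 carries a phenyl on such a chain carbon, as compound 1 does, along with a defined stereocentre that no measured compound has, so its contribution is unknown. On this evidence, no change beyond the scatter is expected in this assay, and the estimated step is a 1.2-fold lower number from compound 3 to compound 4 (0.07 log units; within the scatter). The expected value for compound 4 is 3400 nM, with an estimated range of 1500 nM to 7500 nM.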

Compound 4, half-maximal inhibitory concentration: 5120 nM
Compound 4: the middle estimate sits 1.5-fold (0.18 log units) below what was measured; the range from low to high includes it.
By their numbers in this assay, from the lowest: compounds 1, 3, 4 and 2 (each within the scatter of the next, the first and the last beyond it).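

In this assay, replacing 2-acetamidoethyl with 1-phenylethyl on the amine nitrogen stays within the scatter (a 1.3-fold higher number from compound 3 to compound 4 (0.11 log units; within the scatter)), and so does replacing methyl with 1-phenylethyl at the same nitrogen (a 1.5-fold lower number from compound 2 to compound 4 (0.16 log units; within the scatter)). Methyl in place of hydrogen on the saturated chain carbon bound to an amine nitrogen and an aromatic carbon, which also brings the defined stereocentre, likewise stays within the scatter (a 1.5-fold higher number from compound 1 to compound 4 (0.19 log units; within the scatter)), so compound 4 cannot be told apart from compound 1, compound 2 or compound 3, and the one step beyond the scatter remains the modest one (a 2.2-fold higher number from compound 1 to compound 2 (0.35 log units; beyond the scatter)), which the phenyl-bearing compound 4 does not repeat against compound 2. No measurement shown here accounts for these numbers.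

Going by these compounds, the mirror-image form of 1-phenylethyl remains open, so nothing can be said of whether the stereocentre itself matters in this assay. Also open is how this amine nitrogen would respond to a much longer chain, a terminal carboxylic acid or a second amine in the substituent, since every group shown so far leaves the number within a narrow span.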